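Piperidine in place of an open-chain sulfonamide amine

This account rests on a few compounds, and the source may have more. Where it says the series, first, only, none or still open, it means among the compounds named here.

Compound 1 `CCOC(=O)[C@@H]1CCCN(S(=O)(=O)c2ccc(S(=O)(=O)N(CC)C(C)C)cc2)C1` is the starting point. In a functional assay on MIA PaCa-2 cells (Homo sapiens) for inhibition, read by MTT assay, with a stated time of 7 days (a lower number here means a stronger inhibitor, a higher number a weaker inhibitor), compound 1 gives 1000 nM, the higher of the two numbers recorded in the set. Compound 3 `CCN(CC)S(=O)(=O)c1ccc(S(=O)(=O)N2CCC[C@@H](C(=O)N3CCN(c4nc(C(F)(F)F)no4)CC3)C2)cc1` gives 600 nM in this assay, a result that sits within the scatter of the result for compound 1, so no order between the two can be drawn. Compound 2 `CCOC(=O)N1CCC[C@@H](S(=O)(=O)c2ccc(S(=O)(=O)N(CC)CC)cc2)C1` reaches only a limit of the assay, > 30000 nM. Among the measured compounds shown here, the one result without a number is the limit of > 30000 nM in this assay, at which 1 of the 3 values shown sits.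

Compound 4 `CCOC(=O)[C@@H]1CCCN(S(=O)(=O)c2ccc(S(=O)(=O)N3CCCCC3)cc2)C1` has not yet been measured. It differs from compound 1 in one place: piperidin-1-yl in place of ethyl(isopropyl)amino on a sulfonyl sulfur. For the measured compounds named here, nothing in the measured set shows what this change does, since no pair of measured compounds differs in the same way. The step is therefore expected to be small, with no direction beyond the scatter, and the change from compound 1 to compound 4 is estimated at a 1.2-fold higher number from compound 1 to compound 4 (0.08 log units; within the scatter). Compound 4 is expected to give about 1200 nM in this assay, most likely between 400 nM and 4000 nM.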

Compound 4, half-maximal inhibitory concentration: 2900 nM
Compound 4: middle estimate off by 2.4-fold (0.38 log units), on the low side, and the stated range covers the measured number.
By their numbers in this assay, from the lowest: compounds 3 and 1 (each within the scatter of the next); then compound 4. At a limit, above all of these: compound 2.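

Piperidin-1-yl in place of ethyl(isopropyl)amino on a sulfonyl sulfur gives, in this assay, a 2.9-fold higher number from compound 1 to compound 4 (0.46 log units; beyond the scatter), the first step in this set that can be read, and a modest one. The two groups have the same heavy atoms, 5 carbon and 1 nitrogen, and differ in that the entering group is a ring, so this position does respond to a change of that kind. Nothing measured here bears on why the number moves.

Going by these compounds, whether a morpholin-4-yl ring or a small open-chain dimethylamino group at this sulfonyl sulfur would lie nearer to compound 1 or to compound 4 remains open. Also open, on these data alone, is whether the same exchange would give a step of similar size with the amide side of compound 3 in place.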